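Swapping Cyclopentyl for Hydroxypyridine: Expected Cytotoxicity Shift

The source may report more compounds than this note shows. Statements on the series, on what has been measured and on what is new or still open speak of the compounds shown alone.

Compound 2 `O=C(Nc1ccc(NCC2CCCC2)cc1Cl)c1cc(Cl)ccc1O` is the reference point. In an ADME assay on A549 cells (Homo sapiens) for cytotoxicity, read by resazurin assay, with a stated time of 48 h (on this read-out lower numbers stand for higher toxicity in this test and higher numbers for lower toxicity in this test), compound 2 gives 21500 nM, the lowest of the two numbers recorded. Its nearest neighbour, compound 3 `O=C(Nc1ccc(NCc2cccnc2Cl)cc1Cl)c1cc(Cl)ccc1O`, gives 101000 nM in this assay; the step between them, a 4.7-fold higher number from compound 2 to compound 3 (0.67 log units; beyond the scatter), ran toward lower toxicity. In this assay compound 1 `CC(=O)Nc1ccc(NC(=O)c2cc(Cl)ccc2O)c(Cl)c1` gives "not determined" (no result reported). The new compound 4 `O=C(Nc1ccc(NCc2ccc(O)nc2)cc1Cl)c1cc(Cl)ccc1O` differs from compound 2 by 6-hydroxypyridin-3-yl in place of cyclopentyl on a saturated chain carbon bound to a nitrogen on an aromatic ring. Among the compounds with values here, the only step that bears on this is the one from compound 2 to compound 3, which likewise put a six-membered aromatic ring with one hetero atom in place of cyclopentyl; it was modest and beyond the scatter. A step of similar size and direction is therefore expected, a 3.3-fold higher number from compound 2 to compound 4 (0.51 log units; beyond the scatter). Compound 4 is estimated to give 70000 nM, within a range from 25000 nM to 200000 nM.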

Compound 4, half-maximal cytotoxic concentration: 98500 nM
Compound 4: middle estimate off by 1.4-fold (0.15 log units), on the low side; measured number inside the range.
By their numbers in this assay, from the lowest: compound 2; then compounds 4 and 3 (each within the scatter of the next).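

In this assay, a second aromatic ring on this saturated chain carbon, 6-hydroxypyridin-3-yl, also gives a higher number than cyclopentyl (a 4.6-fold higher number from compound 2 to compound 4 (0.66 log units; beyond the scatter)). Exchanging 2-chloropyridin-3-yl for 6-hydroxypyridin-3-yl produces no real change (a 1.0-fold lower number from compound 3 to compound 4 (0.01 log units; within the scatter)), so in these three compounds the step follows the loss of cyclopentyl, and the two ring substituents cannot be told apart. No measured evidence here explains the step.

Still open, from the compounds shown here alone, is whether a plain phenyl ring would match the two pyridinyl groups. A piperidinyl ring, which is non-aromatic but contains nitrogen, could instead match cyclopentyl.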